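Methoxy-to-hydroxypiperidinyl swap on the acylguanidine series

The source may report more compounds than this note shows. Statements on the series, on what has been measured and on what is new or still open speak of the compounds shown alone.

Going by the values given here, compound 1 `CCc1cc(OC)c(S(C)(=O)=O)cc1C(=O)N=C(N)N` gives the lowest of the three numbers so far: in a functional assay for inhibition of sodium/hydrogen exchanger (Oryctolagus cuniculus) (on this read-out lower numbers stand for stronger inhibition and higher numbers for weaker inhibition), compound 1 gives 30 nM. Compound 2 `COc1cc(Cl)c(C(=O)N=C(N)N)cc1S(C)(=O)=O` sits close to it, giving 40 nM in this assay, a step of a 1.3-fold higher number from compound 1 to compound 2 (0.12 log units; within the scatter). Compound 3 `COc1ccc(C(=O)N=C(N)N)cc1S(C)(=O)=O` gives 270 nM in this assay; the steps of a 9.0-fold higher number from compound 1 to compound 3 (0.95 log units; beyond the scatter) and a 6.8-fold higher number from compound 2 to compound 3 (0.83 log units; beyond the scatter) are the only ones beyond the scatter, and both concern the ethyl group's position.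

Compound 4 `CCc1cc(N2CCC(O)CC2)c(S(C)(=O)=O)cc1C(=O)N=C(N)N` differs from compound 1 in another place: 4-hydroxypiperidin-1-yl in place of methoxy on an aromatic carbon, the site being ortho to the methylsulfonyl group and meta to the ethyl group. Among the compounds with values here, none of the measured steps touches this position, so no measured step bears on the change directly; the ethyl group, whose loss cost compound 3 in this assay, is kept in compound 4. The expectation is therefore a step of a 2.0-fold higher number from compound 1 to compound 4 (0.30 log units; within the scatter), not clearly beyond the scatter in either direction, with a wide range. Compound 4 is estimated at 60 nM in this assay, between 15 nM and 300 nM.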

Compound 4, half-maximal inhibitory concentration: 41 nM
For compound 4 the middle estimate is 1.5-fold (0.17 log units) above the measured one; the measured number falls inside the stated range.
By their numbers in this assay, from the lowest: compounds 1, 2 and 4 (each within the scatter of the next); then compound 3.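

Going by these compounds alone, the step of a 1.4-fold higher number from compound 1 to compound 4 (0.14 log units; within the scatter) in this assay is the first reading at the site ortho to a methylsulfonyl group and meta to an ethyl group, since the earlier steps changed only the ethyl position. At this site, 4-hydroxypiperidin-1-yl, with its six-membered non-aromatic ring and hydrogen-bond donor, stands in place of methoxy with a difference that stays within the scatter. No measurement at hand accounts for the two groups reading alike.

From the compounds shown here alone, whether the hydroxyl matters apart from the ring stays open, and an unsubstituted piperidin-1-yl or a morpholin-4-yl group would bear on that. Also open, going by these compounds, is how this site responds to an open-chain amine or a carboxylic acid, and whether the swap reads the same with chloro or hydrogen in place of ethyl.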